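The source may report more compounds than this note shows. Statements on the series, on what has been measured and on what is new or still open speak of the compounds shown alone.

Series notes. Compound 1 `O=C1NCCN(c2cccc(O)c2)N1` carries a hydroxy group on the six-membered aromatic ring of carbon only of the shared core; in an assay on RBL-1 cells for inhibition of Polyunsaturated fatty acid 5-lipoxygenase (Rattus norvegicus) (on this read-out lower numbers stand for stronger inhibition and higher numbers for weaker inhibition), compound 1 gives 32000 nM. Compound 2 `O=C1NCCN(c2cccc(-c3ccccn3)c2)N1` has a pyridin-2-yl group there instead, and in this assay compound 2 gives 30000 nM. Within the data shown here, the single measured step, a 1.1-fold lower number from compound 1 to compound 2 (0.03 log units; within the scatter), leaves the two compounds level. On paper compound 2 holds the smaller of the two numbers, but its gap to compound 1 is within the scatter, so no order between them is established.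

Compound 3 `O=C1NCCN(c2cccc(-c3ccsc3)c2)N1` is not yet measured. It differs from compound 2 by thiophen-3-yl in place of pyridin-2-yl on an aromatic carbon. Among the measured compounds shown here, the only step that bears on this change is the earlier exchange at the same place, a 1.1-fold lower number from compound 1 to compound 2 (0.03 log units; within the scatter), which did not move the number beyond the scatter. Nothing measured shows that swapping the aromatic substituent at this place shifts this assay; a step of no more than the scatter is therefore expected, in either direction, a 1.1-fold lower number from compound 2 to compound 3 (0.05 log units; within the scatter). The estimate for compound 3 in this assay is 27000 nM, within 9000 nM to 80000 nM.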

Compound 3, half-maximal inhibitory concentration: 4900 nM
The estimate for compound 3 lay 5.5-fold (0.74 log units) above the measured number; measured number outside the range, below it.
By their numbers in this assay, from the lowest: compound 3; then compounds 2 and 1 (each within the scatter of the next).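

The place on the aromatic ring is not indifferent to its substituent in this assay: thiophen-3-yl in place of pyridin-2-yl gives a 6.1-fold lower number from compound 2 to compound 3 (0.79 log units; beyond the scatter), and thiophen-3-yl in place of hydroxy gives a 6.5-fold lower number from compound 1 to compound 3 (0.81 log units; beyond the scatter), so the level result for the first two compounds did not hold for every aromatic substituent. Compound 3 therefore holds the lowest number of the three, and an aromatic ring at this place is not enough on its own, since compound 2 also carries one and stays level with compound 1; between compound 2 and compound 3, however, ring size and hetero atom change together, with a six-membered aromatic ring holding nitrogen giving way to a five-membered one holding sulfur. No data on hand explain the step.

Going by these compounds, it remains open whether the ring size or the hetero atom carries the step, which phenyl, thiophen-2-yl or furan-3-yl at the same place could help to separate. On these data alone, it also remains open whether a methyl, chloro or methoxy group on the thiophene ring would move the number further in either direction.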